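This account rests on a few compounds, and the source may have more. Where it says the series, first, only, none or still open, it means among the compounds named here.

Measured in a functional assay on B16 cells (Mus musculus) for inhibition; a higher number here means a weaker inhibitor, a lower number a stronger inhibitor:
compound 1 `CC(C)CN(NC(=O)OCc1ccccc1)C(=O)CN(Cc1ccccc1)/N=C/c1ccccc1B(O)O`: 65500 nM
compound 2 `CC(C)CN(CC(=O)N(CC(C)C)NC(=O)OCc1ccccc1)/N=C/c1cccc(B(O)O)c1`: 53900 nM
compound 3 `CC(C)CN(NC(=O)OCc1ccccc1)C(=O)CN(Cc1ccccc1)/N=C/c1cccc(B(O)O)c1`: 20400 nM

Of these three, compound 3 has the lowest number and is the strongest inhibitor. Compound 4 `CC(C)CN(NC(=O)OCc1ccccc1)C(=O)CN(Cc1cccnc1)/N=C/c1cccc(B(O)O)c1` differs from it in one place: pyridin-3-yl in place of phenyl on a saturated chain carbon bound to an amine nitrogen. This puts pyridin-3-yl in place of phenyl on a saturated chain carbon bound to an amine nitrogen. The closest evidence is a 2.6-fold lower number from compound 2 to compound 3 (0.42 log units; beyond the scatter), a modest step that brought in phenyl at that same place. The other measured step, a 3.2-fold lower number from compound 1 to compound 3 (0.51 log units; beyond the scatter), lies elsewhere in the molecule and indicates only a typical size. Within the data shown here, no measured step alters the ring itself, so a small rise is expected, no larger than those modest steps. The expected change is a 1.5-fold higher number from compound 3 to compound 4 (0.17 log units; within the scatter). For compound 4 the estimated value is 30000 nM, with an expected range from 11000 nM to 75000 nM.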

Compound 4, half-maximal inhibitory concentration: 74900 nM
Estimate against measurement, compound 4: 2.5-fold (0.40 log units) below, within the range that was stated.
By their numbers in this assay, from the lowest: compound 3; then compounds 2, 1 and 4 (each within the scatter of the next).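

In this assay, a single ring nitrogen matters at this place on a saturated chain carbon bound to an amine nitrogen: pyridin-3-yl in place of phenyl gives a 3.7-fold higher number from compound 3 to compound 4 (0.56 log units; beyond the scatter) as a modest step. Against isopropyl, pyridin-3-yl gives a 1.4-fold higher number from compound 2 to compound 4 (0.14 log units; within the scatter) and so keeps none of the advantage printed for phenyl. No measured evidence accounts for this result. Open, on these data alone, is whether pyridin-4-yl, 4-fluorophenyl or a cyclohexyl ring at this place would stay with compound 3 or with compound 4.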